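Swapping the aryl group on the amine nitrogen

This account rests on a few compounds, and the source may have more. Where it says the series, first, only, none or still open, it means among the compounds named here.

Measured compounds:
compound 1 `O=C1C(Nc2ccccc2)=CC(=O)c2c1nc1n2[C@H]2OC[C@@H](O)[C@H]2OC1` — 3560 nM
compound 2 `CCOc1ccc(NC2=CC(=O)c3nc4n(c3C2=O)[C@H]2OC[C@@H](O)[C@H]2OC4)cc1` — 3210 nM

In a functional assay on ECa-109 cells for inhibition, with ECa-109 cell line (Homo sapiens) as the target, read by sulforhodamine B assay (a lower number here means a stronger inhibitor, a higher number a weaker inhibitor), compound 1 gives 3560 nM. Compound 2 gives 3210 nM in this assay. Of the two numbers, that of compound 2 is the lower one, but compound 1 lies within the scatter of it, so the two cannot be told apart. Compound 3 `O=C1C=C(Nc2cccc(Cl)c2)C(=O)c2c1nc1n2[C@H]2OC[C@@H](O)[C@H]2OC1` is not yet measured. It differs from compound 2 by 3-chlorophenyl in place of 4-ethoxyphenyl on an amine nitrogen. Among the compounds with values here, no step between measured compounds matches this change; the two measured compounds, which differ only in the group on that amine nitrogen, give numbers within the scatter of each other, and that is all the data show about this position. Compound 3 is therefore expected to move by no more than a 1.0-fold higher number from compound 2 to compound 3 (0.01 log units; within the scatter), a step within the scatter. Compound 3 is estimated at 3300 nM in this assay, with a range from 1500 nM to 7500 nM.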

Compound 3, half-maximal inhibitory concentration: 4690 nM
For compound 3 the middle estimate is 1.4-fold (0.15 log units) below the measured one; low and high end bracket the measured number.
By their numbers in this assay, from the lowest: compounds 2, 1 and 3 (each within the scatter of the next).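

In this assay, 3-chlorophenyl in place of 4-ethoxyphenyl on the amine nitrogen gives a 1.5-fold higher number from compound 2 to compound 3 (0.16 log units; within the scatter) and so does not separate the two compounds. This extends what compounds 1 and 2 showed: an aryl group carrying chlorine and no oxygen also stays within the scatter at this position, so all three aryl groups shown give numbers that cannot be told apart. Nothing available here offers an explanation for this result.

The compounds shown leave open whether a group with no aromatic ring on that nitrogen, such as a longer alkyl chain, or a phenyl ring carrying a carboxylic acid or an amine, would give a step beyond the scatter. They also leave open how 4-chlorophenyl would compare with 3-chlorophenyl.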